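Swapping the ring on the core nitrogen of compound 1

The compounds below may be only part of what the source reports. "The series", "measured", "known", "first", "only" and "open" are said of these compounds alone.

Measured compounds:
- compound 1, `CN1CCN(c2ccc(Nc3ncc4nc(Nc5ccc(F)cc5)n([C@H]5CCCNC5)c4n3)cc2)CC1`: 38 nM
- compound 2, `CN1CCN(c2ccc(Nc3ncc4nc(Nc5ccc(F)cc5)n([C@H]5CCCC(NC(=O)OC(C)(C)C)C5)c4n3)cc2)CC1`: 120 nM
- compound 3, `CC(=O)N1CC[C@H](n2c(Nc3ccccc3)nc3cnc(Nc4ccc(N5CCN(C)CC5)cc4)nc32)C1`: 260 nM

In a functional assay on HCC827 cells (Homo sapiens) for antiproliferative activity, read by MTT assay, with a stated time of 72 h (on this read-out lower numbers stand for stronger inhibition and higher numbers for weaker inhibition), compound 1 gives 38 nM, the lowest of the three numbers. Compound 2 gives 120 nM, a gap beyond the scatter, and compound 3 gives 260 nM, further still. For the measured compounds named here, no pair here differs in only one place, so these are simply the values as they stand.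

Compound 4, `CNC(=O)CN1CC[C@H](n2c(Nc3ccc(F)cc3)nc3cnc(Nc4ccc(N5CCN(C)CC5)cc4)nc32)C1`, has not yet been tested. Relative to compound 1 the change is 1-((methylcarbamoyl)methyl)pyrrolidin-3-yl in place of piperidin-3-yl on an aromatic nitrogen. Both compound 2 and compound 3 carry a saturated ring whose nitrogen bears a group rather than a hydrogen, and both sit above compound 1, so a similar direction is expected here: a moderate rise, beyond the scatter but not large.

Compound 4 is therefore expected at about 100 nM, within 40 nM to 250 nM. This estimate corresponds to a step of a 2.6-fold higher number from compound 1 to compound 4 (0.42 log units; beyond the scatter).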

Compound 4, half-maximal inhibitory concentration: 1520 nM
Compound 4: the middle estimate sits 15-fold (1.18 log units) below what was measured; measured number above the stated range.
By their numbers in this assay, from the lowest: compound 1; then compound 2; then compound 3; then compound 4.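

Among the compounds shown, this is the first comparison in which only the group on the aromatic nitrogen changes, and in this assay it gives a 40-fold higher number from compound 1 to compound 4 (1.60 log units; beyond the scatter), so what sits at this position clearly matters. The swap changes two things at once, a six-membered ring for a five-membered one and a ring nitrogen bearing hydrogen for one bearing the (methylcarbamoyl)methyl chain, and a single step cannot separate the two. No measurement at hand accounts for the rise.

Still open, on these data alone, is which of the two changes matters: plain pyrrolidin-3-yl would isolate the ring size, while piperidin-3-yl carrying the same chain on its nitrogen would isolate the chain. Also open, as far as these compounds go, is how a carboxylic acid or a longer chain on that ring nitrogen would read here.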